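Benzylsulfanyl triazole series: step to the ethyl benzyl analogue

This account rests on a few compounds, and the source may have more. Where it says the series, first, only, none or still open, it means among the compounds named here.

Compound 3 `C#CCSc1nnc(CC)n1N1C(=O)c2ccccc2C1=O` stands only at a limit: in a functional assay on MKN-45 cells (Homo sapiens) for cytotoxicity, read by MTT assay, with a stated time of 48 h (a higher number here means a weaker inhibitor, a lower number a stronger inhibitor), compound 3 gives > 200000 nM, a limit of the assay rather than a number. Compound 2 `C#CCSc1nnc(C)n1N1C(=O)c2ccccc2C1=O` likewise gives > 200000 nM in this assay, again a limit. Compound 1 `Cc1nnc(SCc2ccccc2)n1N1C(=O)c2ccccc2C1=O` gives > 200000 nM in this assay, also a limit. The steps a step that the two limits leave unreadable from compound 1 to compound 2 and a step that the two limits leave unreadable from compound 2 to compound 3 therefore cannot be sized; the limit of > 200000 nM in this assay, at which 3 of the 3 values shown sit, is all that these three values offer. Compound 4 `CCc1nnc(SCc2ccccc2)n1N1C(=O)c2ccccc2C1=O` differs from compound 3 by phenyl in place of ethynyl on a saturated chain carbon bound to a sulfur. The step from compound 1 to compound 2 covers the same exchange in the reverse direction, but with both ends at a limit it gives no size either. With nothing in the series resolved away from the limit, the step from compound 3 to compound 4 is expected to be a step that the limit leaves unreadable from compound 3 to compound 4, that is, no movement that can be read. Compound 4 is expected to return 300000 nM, in the range 150000 nM to 1000000 nM, most likely reported once more as a limit.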

Compound 4, half-maximal inhibitory concentration: > 200000 nM
Compound 4 was reported as a limit (the forecaster's own chance of this, stated with the estimate: 90%); the middle value is on the limit's open side.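

In this assay compound 4 gives > 200000 nM, again a limit. The steps to compound 4 from compound 3 and from compound 1 cannot be read: the limit of > 200000 nM in this assay, at which 4 of the 4 values shown sit. The compounds shown leave open whether any change on the shared core would bring a value away from that limit.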